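From methoxy to methyl on the aryl ring

The source may hold more compounds than are shown below. What is called first, only, known or untested is meant among the compounds shown, and "the series" means these compounds.

Compound 1 `COC(=O)[C@H](CO)NC(=O)/C=C/c1ccc(F)cc1`: "not determined" (no result reported) in an ADME assay on Vero cells (Chlorocebus sabaeus) for cytotoxicity, read by WST assay, tested at 100 ug/mL; a higher number here means a weaker effect of the compound at the concentration tested, a lower number a stronger effect.
Compound 2 `COC(=O)[C@H](CO)NC(=O)/C=C/c1ccc(OC)cc1`: 103%.

Compound 2 holds the only number shown in this assay; compound 1 has no result there, so compound 2 stands alone, with a read-out that points to no cytotoxic effect at the concentration tested. Compound 3 `COC(=O)[C@H](CO)NC(=O)/C=C/c1ccc(C)cc1` differs from compound 2 by methyl in place of methoxy on an aromatic carbon. Within the data shown here, no step between measured compounds is available, and the expected step rests on compound 2 alone: none beyond the scatter, in no particular direction. Compound 3 is expected to give 100% in this assay, within 85% to 112%. For compound 3 this means an expected step of a number 3 percentage points lower from compound 2 to compound 3 (within the scatter).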

Compound 3, a percentage reported as activity, at one concentration (the size of the read-out at that concentration, not a potency): 101%
Compound 3: the middle estimate sits 1 percentage points below what was measured; measured number inside the range.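

In this assay, methyl in place of methoxy on this aromatic carbon, para to a large group, gives a number 2 percentage points lower from compound 2 to compound 3 (within the scatter) and so leaves the read-out within the scatter. Compound 2 alone could not show whether the read-out moves with the group at this position, and for this one change it does not. Nothing measured here bears on why the two groups read alike. Going by these compounds, whether an amine, a carboxylic acid or a longer chain on this carbon would read the same way in this assay stays open, as does the effect of changing the methyl ester of the shared core.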